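This account rests on a few compounds, and the source may have more. Where it says the series, first, only, none or still open, it means among the compounds named here.

Working notes on the series. Compound 1 `Cc1ccc(C(=O)OC2(C(=O)Nc3ccc([N+](=O)[O-])cc3)CCCCC2)cc1` and compound 2 `COc1ccc(C(=O)OC2(C(=O)Nc3ccc([N+](=O)[O-])cc3)CCCCC2)cc1` share one core and differ only at the aryl ester. In a functional assay on MCF7 cells (Homo sapiens) for inhibition, read by MTT assay, with a stated time of 72 h (a higher number here means a weaker inhibitor, a lower number a stronger inhibitor), compound 1 gives 9.8 nM, and in the same assay compound 2 gives 41.2 nM. Among the measured compounds shown here, the single measured step, a 4.2-fold higher number from compound 1 to compound 2 (0.62 log units; beyond the scatter), leaves compound 2 with the highest number of the two measured so far.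

Compound 3 `Cc1ccccc1C(=O)OC1(C(=O)Nc2ccc([N+](=O)[O-])cc2)CCCCC1` is not yet measured. It differs from compound 2 by 2-methylphenyl in place of 4-methoxyphenyl on a carbonyl carbon. For the measured compounds named here, the one step that bears on this is the methoxy-for-methyl exchange, which gave a modest rise beyond the scatter; compound 3 returns to a methyl, though at another ring position than in compound 1, for which no step is on hand. Compound 3 is therefore expected to move back toward compound 1, by about a 2.7-fold lower number from compound 2 to compound 3 (0.44 log units; beyond the scatter) in this assay, and its estimated value is 15 nM, within a range of 5 nM to 50 nM.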

Compound 3, half-maximal inhibitory concentration: 516 nM
The estimate for compound 3 lay 34-fold (1.54 log units) below the measured number; the whole stated range lies below it.
By their numbers in this assay, from the lowest: compound 1; then compound 2; then compound 3.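

In this assay, moving the methyl on the aryl ester from 4-methylphenyl to 2-methylphenyl gives a 53-fold higher number from compound 1 to compound 3 (1.72 log units; beyond the scatter), so the ring position of a group here can matter more than the methoxy-for-methyl exchange first suggested. The change of 4-methoxyphenyl to 2-methylphenyl is also large, with a 13-fold higher number from compound 2 to compound 3 (1.10 log units; beyond the scatter), which makes compound 3 the weakest inhibitor of the three. No supporting data bear on the origin of this loss.

The compounds shown leave open whether the loss belongs to the methyl itself or would follow any group at that ring position. They also leave open how an amine or a carboxylic acid would behave on this ring, at either position.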